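This account rests on a few compounds, and the source may have more. Where it says the series, first, only, none or still open, it means among the compounds named here.

The series shares one core, varied at the benzyl end and on the aniline-like ring. Compound 1 `COc1ccc(Cc2nnc(CN(c3cccc(Cl)c3C)S(=O)(=O)c3ccc(C)cc3)o2)cc1` gives 39.8 nM in a functional assay on CHO cells for antagonist activity at prostaglandin E2 receptor EP1 subtype (Homo sapiens), read by FLIPR and calcium flux; a lower number here means a stronger inhibitor, a higher number a weaker inhibitor. Compound 2 `CCOc1ccc(Cc2nnc(CN(c3cccc(Cl)c3C)S(=O)(=O)c3ccc(C)cc3)o2)cc1` gives 50.1 nM in this assay, and compound 3 `CCOc1ccc(Cc2nnc(CN(c3cccc(Cl)c3Cl)S(=O)(=O)c3ccc(C)cc3)o2)cc1` gives 31.6 nM in this assay. Compound 2 thus carries the highest of the three numbers, yet its gaps to the other two lie within the scatter, so no order among them can be claimed. Compound 4 `Cc1ccc(S(=O)(=O)N(Cc2nnc(Cc3ccc(N(C)C)cc3)o2)c2cccc(Cl)c2C)cc1` differs from compound 2 by dimethylamino in place of ethoxy on an aromatic carbon. Going by the values given here, of the measured steps, the one from compound 1 to compound 2 touches the same position and gave a 1.3-fold higher number from compound 1 to compound 2 (0.10 log units; within the scatter); the step from compound 2 to compound 3 changes another ring and gave a 1.6-fold lower number from compound 2 to compound 3 (0.20 log units; within the scatter). Neither change moved the number beyond the scatter, and nothing measured here probes a nitrogen-linked group at this place. It is therefore expected that compound 4 shows at most a small step, a 1.1-fold lower number from compound 2 to compound 4 (0.05 log units; within the scatter), in this assay. The estimate for compound 4 in this assay is 45 nM, with a range from 18 nM to 110 nM.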

Compound 4, inhibition constant: 20 nM
Compound 4: middle estimate off by 2.3-fold (0.35 log units), on the high side; the measured number falls inside the stated range.
By their numbers in this assay, from the lowest: compounds 4, 3, 1 and 2 (each within the scatter of the next, the first and the last beyond it).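

Going by these compounds alone, putting dimethylamino in place of ethoxy on this aromatic carbon, para to a large group, gave a 2.5-fold lower number from compound 2 to compound 4 (0.40 log units; beyond the scatter) in this assay and is the only step to pass the scatter, so this position is not as indifferent as the small step between methoxy and ethoxy had suggested. Set against methoxy, the same group gave a 2.0-fold lower number from compound 1 to compound 4 (0.30 log units; within the scatter) and stays inside the scatter, so the shift holds only against ethoxy and remains modest. Nothing available bears on why dimethylamino and ethoxy differ at this place.

Still open, as far as these compounds go, is whether the nitrogen itself matters, which a primary amine or a diethylamino group at this position would test. From the compounds shown here alone, it is also open whether dimethylamino keeps its step when chloro replaces the methyl on the other ring, as in compound 3.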